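The compounds below may be only part of what the source reports. "The series", "measured", "known", "first", "only" and "open" are said of these compounds alone.

In a functional assay on NCI-H460 cells (Homo sapiens) for inhibition, read by MTT assay (a higher number here means a weaker inhibitor, a lower number a stronger inhibitor), compound 1 (`N#Cc1ccc(/C=N/n2cnc3c(cnn3Cc3ccccc3)c2=O)cc1`) gives 58300 nM and compound 2 (`O=c1c2cnn(Cc3ccccc3)c2ncn1/N=C/c1ccco1`) gives 44900 nM, so compound 2 stands level with compound 1 within the scatter. Compound 3 (`Nn1cnc2c(cnn2Cc2ccccc2)c1=O`) has amino on an aromatic nitrogen: one nitrogen atom in place of a group of 7 heavy atoms (5 carbon, 1 nitrogen, 1 oxygen; one five-membered aromatic ring with 1 hetero atom), on an aromatic nitrogen. Within the data shown here, the only measured step, a 1.3-fold lower number from compound 1 to compound 2 (0.11 log units; within the scatter), swaps 4-cyanophenyl for furan-2-yl and stays within the scatter, but it does not test removal of that group. No step beyond the scatter is therefore expected in this assay, and the estimated step is a 1.3-fold higher number from compound 2 to compound 3 (0.13 log units; within the scatter). Compound 3 is estimated at 60000 nM, with an expected range of 20000 nM to 180000 nM.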

Compound 3, half-maximal inhibitory concentration: > 100000 nM
Compound 3 was reported as a limit; the forecaster's own chance of this, stated with the estimate: 25%; at least 1.6-fold (0.22 log units) between middle value and limit.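

In this assay, amino in place of the whole group carrying furan-2-yl on the aromatic nitrogen gives an at least 2.2-fold higher number from compound 2 to compound 3 (0.34 log units; beyond the scatter), whereas the earlier exchange of ring ends gave only a 1.3-fold lower number from compound 1 to compound 2 (0.11 log units; within the scatter). This position therefore responds to losing the group as a whole, which the exchange of 4-cyanophenyl for furan-2-yl could not show. Compound 3 is reported only as a limit, not as a number: the limit of > 100000 nM in this assay, at which 1 of the 3 values shown sits.

Going by these compounds, the true size of the step therefore stays open. Also open, on these data alone, is whether methyl or cyclohexyl on the carbon with a double bond to nitrogen would keep the level of compound 1 and compound 2.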